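Dropping the chloro from compound 2: what remains

A few compounds are considered here, and "the series" means these few. Any claim that something is new, unique, unknown or untested is made for them only; others in the source may bear on it.

Measured so far:
compound 1 `COc1ccc(OC)c(/C=C/c2nnc(Nc3ccc(Cl)cc3)o2)c1` — in this assay: > 100000 nM
compound 2 `COc1ccc(OC)c(/C=C/C(=O)N/N=C/c2ccc(Cl)cc2)c1` — in this assay: > 100000 nM

Compound 2 was tested in a functional assay on HCT-116 cells (Homo sapiens) for antiproliferative activity, read by sulforhodamine B assay, with a stated time of 48 h; a higher number here means that more compound is tolerated, a lower number that less compound is tolerated. For compound 2 the value > 100000 nM is a limit of the assay, not a number. For compound 1 the value > 100000 nM is likewise a limit. Among the compounds with values here, both results therefore sit at the limit of > 100000 nM in this assay, at which 2 of the 2 values shown sit, and no numerical step can be drawn between them; the two compounds merely share a limit.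

Compound 3 `COc1ccc(OC)c(/C=C/C(=O)N/N=C/c2ccccc2)c1` has not yet been measured. It differs from compound 2 in one place: hydrogen in place of chloro on an aromatic carbon. Within the data shown here, nothing among the measured results speaks for a change beyond the usual scatter from this replacement, and compound 2 itself offers no number to move from. Compound 3 is accordingly expected to remain at the limit, with an estimated step of a number no higher from compound 2 to compound 3 (the limit leaves the size open). The estimated value of compound 3 is 100000 nM, expected to lie between 40000 nM and 300000 nM.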

Compound 3, concentration lethal to 50% of the cells: 67200 nM
The estimate for compound 3 lay 1.5-fold (0.17 log units) above the measured number, and the stated range covers the measured number.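

Going from the 4-chlorophenyl to the phenyl gives an at least 1.4-fold lower number from compound 2 to compound 3 (0.17 log units; that floor lies within the scatter) in this assay, so compound 3 is the only compound shown that yields a number and not a limit. Within the data shown here, this is the first sign that this aromatic carbon, para to a large group, can bear on the read-out, but the printed floor lies within the scatter, so the data show no change beyond it. The true size of the step stays open because compound 2 stands at a limit and not at a number: the limit of > 100000 nM in this assay, at which 2 of the 3 values shown sit.

On these data alone, how far compound 2 lies past its limit remains unknown, so the chloro can be given no measured share in the result. Also open, as far as these compounds go, is how a fluoro, a methoxy or an amine on the same aromatic carbon would stand in this assay.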